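The source may hold more compounds than are shown below. What is called first, only, known or untested is meant among the compounds shown, and "the series" means these compounds.

Compound 1 `O=C(O)CCCCCCCCCCn1nc(-c2ccccc2)c(-c2ccccc2)c1-c1ccccc1`: 18600 nM
Compound 2 `O=C(O)CCCCCCCn1cc(-c2ccccc2)c(-c2ccccc2)n1`: > 85000 nM

For the measured compounds named here, in a functional assay for inhibition, with Homo sapiens as the target (a lower number here means a stronger inhibitor, a higher number a weaker inhibitor), compound 1 gives 18600 nM, the only actual number so far. Compound 2 stands at > 85000 nM, which is a limit of the assay. Compound 3 `CS(=O)(=O)NC(=O)CCCCCCCCn1nc(-c2ccccc2)c(-c2ccccc2)c1-c1ccccc1` has (methylsulfonyl)carbamoyl in place of 2-carboxyethyl on a saturated chain carbon, eight bonds along the chain from an aromatic nitrogen. Going by the values given here, no measured step covers this change, so no step beyond the scatter is expected in this assay, and no direction is favoured. The expected change is a 1.2-fold lower number from compound 1 to compound 3 (0.07 log units; within the scatter). For compound 3 the estimated value is 16000 nM, with an expected range of 5000 nM to 60000 nM.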

Compound 3, half-maximal inhibitory concentration: 5900 nM
Compound 3: the middle estimate sits 2.7-fold (0.43 log units) above what was measured; the measured number falls inside the stated range.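

In this assay, for the compounds shown here, the end of the chain accepts a change of acid group: (methylsulfonyl)carbamoyl in place of 2-carboxyethyl gives a 3.2-fold lower number from compound 1 to compound 3 (0.50 log units; beyond the scatter) and so the first step beyond the scatter. At this position, on a saturated chain carbon, eight bonds along the chain from an aromatic nitrogen, a free carboxylic acid is thus not needed for a measurable value. Nothing shown here accounts for the size of this step.

Still open, from the compounds shown here alone, is how a primary amide or a (phenylsulfonyl)carbamoyl group would read at the same place. Also open, going by these compounds, is whether a longer chain carrying (methylsulfonyl)carbamoyl would shift the value further.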